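The compounds below may be only part of what the source reports. "The series", "measured", "known", "first", "only" and "open" are said of these compounds alone.

Measured so far in an assay on isolated protein for inhibition of alpha-galactosidase (Coffea arabica), read by spectrophotometry, tested at 1000 uM; a lower number here means less inhibition, a higher number more inhibition at the concentration tested (going by the name of the read-out):
- compound 1, `Cc1ccc([C@H]2NC[C@@H](O)[C@@H]2O)cc1`: 0%
- compound 2, `O[C@H]1[C@H](O)CN[C@@H]1c1ccc(-c2ccccc2)cc1`: 0%

Compound 2 stands level with compound 1 in this assay; its nearest point of comparison is compound 1, and the step of no change at the digits printed from compound 1 to compound 2 (within the scatter) is no change within the scatter. The two share the same core and differ only in the group on an aromatic carbon, phenyl in place of methyl.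

Compound 3, `O[C@H]1[C@H](O)CN[C@@H]1c1ccc(F)cc1`, has not been measured in this assay. Relative to compound 2 the change is fluoro in place of phenyl on an aromatic carbon. Within the data shown here, the one measured step that bears on this position, no change at the digits printed from compound 1 to compound 2 (within the scatter), put phenyl in place of methyl on an aromatic carbon and left the read-out where it was. The change now runs from phenyl to fluoro at the same aromatic carbon. Nothing in the measured pair points to a shift in either direction, so no step beyond the scatter is expected in this assay for compound 3. The estimated step of no change at the digits printed from compound 2 to compound 3 (within the scatter) is therefore flat. Compound 3 is expected to give about 0% in this assay, with a range from 0% to 10%.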

Compound 3, a percentage reported as inhibition, at one concentration (the size of the read-out at that concentration, not a potency): 2%
Compound 3: middle estimate off by 2 percentage points, on the low side; low and high end bracket the measured number.
By their numbers in this assay, from the lowest: compounds 1, 2 and 3 (each within the scatter of the next).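

At this aromatic carbon, fluoro joins methyl and phenyl as a third group in this assay: fluoro in place of phenyl gives a number 2 percentage points higher from compound 2 to compound 3 (within the scatter), and fluoro in place of methyl gives a number 2 percentage points higher from compound 1 to compound 3 (within the scatter). Both steps are within the scatter, so a single fluorine atom, a methyl group and a phenyl ring of 6 heavy atoms do not separate from one another on the shared core, and the flat result from the first pair now extends to a group containing a halogen. No supporting evidence bears on why the read-out stays flat at this position.

Still open, going by these compounds, is whether an amine, a carboxylic acid or a longer alkyl chain on the same aromatic carbon would move the read-out in this assay beyond the scatter, since the three groups here do not include any of these. Also open, on these data alone, is whether a change elsewhere on the shared core, rather than at this aromatic carbon, would give a clear step.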